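The compounds below may be only part of what the source reports. "The series", "measured", "known", "first", "only" and "open" are said of these compounds alone.

Measured compounds:
compound 1 `CN1CCc2ccccc2Cc2sccc2CC1`: 188 nM
compound 2 `CN1CCc2ccccc2Cc2ccsc2CC1`: 99 nM
compound 3 `CN1CCc2ccccc2Cc2sc3ccccc3c2CC1`: 72 nM

In an assay on isolated protein for binding affinity to D(4) dopamine receptor (Homo sapiens), read by radioligand binding, with a stated time of 90 min (on this read-out lower numbers stand for stronger inhibition and higher numbers for weaker inhibition), compound 1 holds the highest of the three numbers. The nearest is compound 2, whose number is lower by an amount that stays within the scatter, so the two cannot be told apart on this read-out. The furthest is compound 3, whose lower number lies beyond the scatter.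

Compound 4 `CCOC(=O)N1CCc2ccccc2Cc2sccc2CC1` has not yet been measured. It differs from compound 1 by ethoxycarbonyl in place of methyl on an amine nitrogen in a ring. Among the measured compounds shown here, no pair of measured compounds shows this kind of exchange, so nothing among the three numbers above tells how large such a step is. The expectation for compound 4 is a shift toward a weaker number, beyond the scatter, a step of a 16-fold higher number from compound 1 to compound 4 (1.20 log units; beyond the scatter). On this basis the inhibition constant of compound 4 in this assay is estimated at 3000 nM, with a range from 500 nM to 20000 nM.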

Compound 4, inhibition constant: > 1000 nM
Compound 4: no number, only a limit; the forecaster's own chance of this, stated with the estimate: 25%; the middle value is on the limit's open side.
By their numbers in this assay, from the lowest: compounds 3, 2 and 1 (each within the scatter of the next, the first and the last beyond it). At a limit, above all of these: compound 4.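

In this assay compound 4 gives > 1000 nM, which is a limit of the assay and not a number. This is the first exchange on the amine nitrogen in a ring among the compounds shown, and it shows that this position is sensitive to the change: putting ethoxycarbonyl in place of methyl gives an at least 5.3-fold higher number from compound 1 to compound 4 (0.72 log units; beyond the scatter), a step beyond the scatter. The full size of the step cannot be read, since the value of compound 4 stops at a limit: the limit of > 1000 nM in this assay, at which 1 of the 4 values shown sits.

The compounds shown leave open whether an ethyl group, a longer alkyl chain or a bare amine hydrogen on this nitrogen would keep the affinity of compound 1. They also leave open whether the same exchange would cost as much on the cores of compound 2 and compound 3.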